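A longer carboxylic acid chain on the core of compound 3

A few compounds are considered here, and "the series" means these few. Any claim that something is new, unique, unknown or untested is made for them only; others in the source may bear on it.

Of the compounds shown here, three sharing one core have been measured in a functional assay on cells for inhibition of leukotriene B4 receptor 1 (Homo sapiens); on this read-out lower numbers stand for stronger inhibition and higher numbers for weaker inhibition. Compound 3, `CC(CCCCOc1cc(-c2ccccc2)cc(-c2ccccc2)n1)C(=O)O`, gives 22 nM, the lowest number of the three. Compound 1, `CC(CCCCOc1cc(-c2ccccc2)cc(-c2ccccc2F)n1)C(=O)O`, gives 70 nM, and the step of a 3.2-fold lower number from compound 1 to compound 3 (0.50 log units; beyond the scatter) separates it from compound 3. Compound 2, `O=C(O)CCCCCOc1cc(-c2ccccc2)cc(-c2ccccc2)n1`, gives 2000 nM, and the step of a 91-fold lower number from compound 2 to compound 3 (1.96 log units; beyond the scatter) shows how strongly the methyl on the chain carbon bound to the carbonyl carbon lowers the number.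

Compound 4, `CC(C)(CCCCCCOc1cc(-c2ccccc2)cc(-c2ccccc2)n1)C(=O)O`, has not yet been measured. It differs from compound 3 in one place: 3-carboxy-3-methylbutyl in place of 1-carboxyethyl on a saturated chain carbon, four bonds along the chain from an oxygen on an aromatic ring. The carbon bound to the carbonyl carbon now carries two methyls instead of one, and the chain between the aromatic oxygen and the carboxylic acid is longer by two saturated carbons. Among the measured compounds shown here, only the step from compound 2 to compound 3 bears on this change, and it concerns the methyl alone; no measured pair shows the effect of lengthening the chain, so that part of the change is untested. Keeping methyl substitution at the carbon bound to the carbonyl carbon argues against a return toward compound 2, while the longer chain leaves room for movement in either direction. A modest rise is therefore expected, a 2.7-fold higher number from compound 3 to compound 4 (0.44 log units; beyond the scatter), and compound 4 is estimated at 60 nM in this assay, within a range from 12 nM to 300 nM.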

Compound 4, half-maximal inhibitory concentration: 100 nM
Compound 4: the middle estimate sits 1.7-fold (0.22 log units) below what was measured; measured number inside the range.
By their numbers in this assay, from the lowest: compound 3; then compounds 1 and 4 (each within the scatter of the next); then compound 2.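

In this assay, the replacement of 1-carboxyethyl by 3-carboxy-3-methylbutyl, which brings a second methyl onto the carbon bound to the carbonyl carbon and lengthens the chain by two saturated carbons, does not come free (a 4.5-fold higher number from compound 3 to compound 4 (0.66 log units; beyond the scatter)). The loss is only modest, however, and much of the gain that separates compound 3 from compound 2 survives on the longer chain with two methyls (a 20-fold lower number from compound 2 to compound 4 (1.30 log units; beyond the scatter)), so this end of the chain accepts a larger group without falling back to the number of compound 2. Nothing available explains the size of either step.

From the compounds shown here alone, the step to compound 4 carries the second methyl and the two extra chain carbons at once, so how much of the rise belongs to each remains open. Also open, going by these compounds, is how an ethyl or a cyclopropane ring on the carbon bound to the carbonyl carbon, or a shorter chain carrying two methyls there, would read on the shared core.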